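The compounds below may be only part of what the source reports. "The series", "measured", "known", "first", "only" and "open" are said of these compounds alone.

Three compounds have been measured in a functional assay on CHO-K1 cells for antagonist activity at prostaglandin E2 receptor EP1 subtype (Homo sapiens), read by FLIPR; on this read-out higher numbers stand for weaker inhibition and lower numbers for stronger inhibition:
compound 1, `Cc1cc(C(=O)O)nn1Cc1cc(Br)ccc1OCc1ccccc1`, gives 15.1 nM;
compound 2, `COc1ccccc1COc1ccc(Br)cc1Cn1nc(C(=O)O)cc1C`, gives 69.2 nM;
compound 3, `Cc1cc(C(=O)O)nn1Cc1cc(Br)ccc1OCc1cccc(Br)c1`, gives 129 nM.

Compound 3 has the highest of the three numbers in this assay. Its nearest neighbour is compound 2, a 1.9-fold higher number from compound 2 to compound 3 (0.27 log units; within the scatter), a gap within the usual scatter, so these two cannot be ranked against each other. Compound 1 lies furthest away, an 8.5-fold higher number from compound 1 to compound 3 (0.93 log units; beyond the scatter).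

Compound 4, `Cc1cc(C(=O)O)nn1Cc1cc(Br)ccc1OCc1cc(Cl)cc(Cl)c1`, has not yet been measured. It differs from compound 3 in one place: 3,5-dichlorophenyl in place of 3-bromophenyl on a saturated chain carbon bound to an oxygen on an aromatic ring. Going by the values given here, two measured steps concern this part of the molecule. Putting a bromine onto the unsubstituted ring of compound 1 gave an 8.5-fold higher number from compound 1 to compound 3 (0.93 log units; beyond the scatter), a rise beyond the scatter. Exchanging one substituted ring for another gave a 1.9-fold higher number from compound 2 to compound 3 (0.27 log units; within the scatter), within the scatter. Going from 3-bromophenyl to 3,5-dichlorophenyl adds halogen rather than removing it, so a further small-to-modest rise in the number is expected, though a result within the scatter of compound 3 would not surprise. Compound 4 is therefore estimated at 220 nM in this assay, within a range of 70 nM to 700 nM, meaning an expected step of a 1.7-fold higher number from compound 3 to compound 4 (0.23 log units; within the scatter).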

Compound 4, inhibition constant: 1120 nM
Compound 4: the middle estimate sits 5.1-fold (0.71 log units) below what was measured; measured number outside the range, above it.
By their numbers in this assay, from the lowest: compound 1; then compounds 2 and 3 (each within the scatter of the next); then compound 4.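

In this assay the ring on this saturated chain carbon proves less forgiving than compounds 2 and 3 alone suggested: 3,5-dichlorophenyl in place of 3-bromophenyl brings an 8.7-fold higher number from compound 3 to compound 4 (0.94 log units; beyond the scatter) in one exchange, about as large as the step that first put a bromine on the phenyl ring. Compounds 2 and 3 could not be ranked, yet compound 4 stands clear of both, with a 16-fold higher number from compound 2 to compound 4 (1.21 log units; beyond the scatter) and, against the plain phenyl, a 74-fold higher number from compound 1 to compound 4 (1.87 log units; beyond the scatter) as the widest gap so far. Nothing available here explains the size of these steps.

On these data alone, two things changed at once, the halogen and the number of halogens, so their shares remain open. A 3-chlorophenyl group at this place would separate them, and a 3,5-dibromophenyl group would test the same question from the bromine side.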